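The source may report more compounds than this note shows. Statements on the series, on what has been measured and on what is new or still open speak of the compounds shown alone.

Measured in a functional assay on MCF-10A cells (Homo sapiens) for antiproliferative activity, with a stated time of 48 h; on this read-out higher numbers stand for an effect only at larger amounts of compound and lower numbers for an effect already at smaller amounts:

- compound 1 `COc1ccc2nc(C)cc(NCc3ccc(F)c(F)c3)c2c1` gives 12000 nM
- compound 2 `COc1ccc2nc(C)cc(NCc3ccc(C(F)(F)F)cc3)c2c1` gives 7600 nM
- compound 3 `COc1ccc2nc(C)cc(NCc3ccc(F)c(C(F)(F)F)c3)c2c1` gives 14300 nM

All three compounds act only at high amounts on this read-out. The gaps from compound 1 to compound 2 and to compound 3 both lie within the scatter of repeated measurements. On these numbers, then, compound 1 cannot be told apart from either of them.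

Compound 4 `COc1ccc2nc(C)cc(NCc3ccc(OC)c(F)c3)c2c1` has not yet been measured in this assay. Its difference from compound 1 is methoxy in place of fluoro on an aromatic carbon. In words, it carries methoxy in place of fluoro on an aromatic carbon, ortho to a fluoro group and para to a large group.

For the measured compounds named here, only one measured step bears on this change, and it also removes a fluoro from an aromatic carbon: trifluoromethyl in its place gives a 1.2-fold higher number from compound 1 to compound 3 (0.08 log units; within the scatter). Going by the values given here, that step stayed within the scatter, but it is thin evidence, since no measured step puts methoxy in place of fluoro. A change beyond the scatter is therefore not expected in this assay, and no direction can be argued.

The expected outcome is a 1.1-fold lower number from compound 1 to compound 4 (0.04 log units; within the scatter).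

For compound 4 the estimated value is 11000 nM, with an expected range from 5000 nM to 25000 nM.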

Compound 4, half-maximal effective concentration: 10300 nM
Compound 4: the middle estimate sits 1.1-fold (0.03 log units) above what was measured; low and high end bracket the measured number.
By their numbers in this assay, from the lowest: compounds 2, 4, 1 and 3 (each within the scatter of the next).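

In this assay, for the compounds shown here, the fluoro para to a large group and ortho to a fluoro group is now changed directly for the first time: methoxy in its place gives a 1.2-fold lower number from compound 1 to compound 4 (0.07 log units; within the scatter). Going by these compounds alone, the only earlier single-place step from compound 1, a 1.2-fold higher number from compound 1 to compound 3 (0.08 log units; within the scatter), replaced the other fluoro group, so it said nothing direct about this position. Here, a swap that brings in 1 hydrogen-bond acceptor, where fluoro counts 0, and 2 heavy atoms in place of 1 leaves compound 4 indistinguishable from compound 1 on this read-out, and no measurement is available that could explain this result.

One methoxy group at one position cannot show how far this indifference extends, and an amine, a carboxylic acid or a longer chain such as butoxy at the same place could still give a number beyond the scatter. As far as these compounds go, it also remains open whether methoxy would behave the same way in place of the other fluoro group, or whether any change on this ring can bring the effect down to much smaller amounts of compound.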